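Thiophen-3-yl for 1-Benzofuran-2-yl on Two Related Cores

This account rests on a few compounds, and the source may have more. Where it says the series, first, only, none or still open, it means among the compounds named here.

Compound 2 `O=c1[nH]cnc2c1c(-c1cc3ccccc3o1)cn2[C@@H]1O[C@H](CO)[C@@H](O)[C@H]1O` and compound 1 `O=c1[nH]cnc2c1c(-c1ccsc1)cn2[C@@H]1O[C@H](CO)[C@@H](O)[C@H]1O` share one core and differ at a single aromatic carbon: thiophen-3-yl in place of 1-benzofuran-2-yl on an aromatic carbon. In a functional assay on CCRF-CEM cells (Homo sapiens), read by MTT assay, with a stated time of 72 h (a lower number here means a stronger inhibitor, a higher number a weaker inhibitor), compound 2 reaches only the assay limit of > 20000 nM. Compound 1 gives 14500 nM in this assay. The step is therefore an at least 1.3-fold lower number from compound 2 to compound 1 (0.13 log units; that floor lies within the scatter), its floor set by the limit of > 20000 nM in this assay, at which 2 of the 3 values shown sit. Compound 3 `Cc1nc(N)c2c(-c3cc4ccccc4o3)cn([C@@H]3O[C@H](CO)[C@@H](O)[C@H]3O)c2n1` carries 1-benzofuran-2-yl on a second core; the difference between the two cores is not broken down here. In this assay compound 3 likewise sits at the limit of > 20000 nM. Compound 4 `Cc1nc(N)c2c(-c3ccsc3)cn([C@@H]3O[C@H](CO)[C@@H](O)[C@H]3O)c2n1` arises from compound 3 by the same change, (thiophen-3-yl in place of 1-benzofuran-2-yl on an aromatic carbon), at the same kind of place. Resting on the step of an at least 1.3-fold lower number from compound 2 to compound 1 (0.13 log units; that floor lies within the scatter), compound 4 is expected to give 25000 nM in this assay, within 9000 nM to 80000 nM. That expectation amounts to a step that the limit leaves unreadable from compound 3 to compound 4.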

Compound 4, half-maximal inhibitory concentration: > 20000 nM
Compound 4: a limit, no number; the forecaster's own chance of this, stated with the estimate: 65%; the middle value does not contradict the limit.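

In this assay compound 4 gives > 20000 nM, which is a limit and not a number, so no step can be read between compound 3 and compound 4. The compounds shown leave open what thiophen-3-yl in place of 1-benzofuran-2-yl does on the core of compound 3: the limit of > 20000 nM in this assay, at which 3 of the 4 values shown sit.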